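Homologating the Acid on the Cyclohexyl Ring

The compounds below may be only part of what the source reports. "The series", "measured", "known", "first", "only" and "open" are said of these compounds alone.

Measured compounds:
compound 1 `COc1ccc(F)cc1-c1c(F)cnc2[nH]c(C3=CCN([C@H]4CC[C@@H](C(=O)O)CC4)CC3)cc12` — 140 ng.h/mL
compound 2 `COc1ccc(F)cc1-c1ccnc2[nH]c(C3=CCN([C@H]4CC[C@@H](C(=O)O)CC4)CC3)cc12` — 160 ng.h/mL

In an ADME assay on the whole organism (Rattus norvegicus) for pharmacokinetics, at a dose of 1 mg/kg by the oral route (a higher number here means more compound in the circulation at the dose given, a lower number less compound in the circulation), compound 1 gives 140 ng.h/mL, and compound 2 gives 160 ng.h/mL; the two stand level, since a 1.1-fold higher number from compound 1 to compound 2 (0.06 log units; within the scatter) lies within the scatter. Compound 3 `COc1ccc(F)cc1-c1c(F)cnc2[nH]c(C3=CCN([C@H]4CC[C@H](CC(=O)O)CC4)CC3)cc12` differs from compound 1 in 4-(carboxymethyl)cyclohexyl in place of 4-carboxycyclohexyl on an amine nitrogen in a ring. Within the data shown here, no measured step touches this change; the only step known, from compound 1 to compound 2, concerns a different position and is itself within the scatter. There is thus no basis to expect a step beyond the scatter, and the expected step is no change at the digits printed from compound 1 to compound 3 (within the scatter). Compound 3 is estimated at 140 ng.h/mL, with a range from 50 ng.h/mL to 400 ng.h/mL.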

Compound 3, area under the concentration-time curve: 140 ng.h/mL
Compound 3: the middle estimate sits on the measured number at the digits printed; the measured number falls inside the stated range.
By their numbers in this assay, from the lowest: compounds 1, 3 and 2 (each within the scatter of the next).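

On the amine nitrogen in a ring, 4-(carboxymethyl)cyclohexyl in place of 4-carboxycyclohexyl gives no change at the digits printed from compound 1 to compound 3 (within the scatter) in this assay. Among these compounds, this is the first measured step at this position, and it shows that this change leaves the number within the scatter on the core of compound 1. No evidence at hand bears on this result.

Still open, going by these compounds, is whether a longer chain bearing the carboxylic acid, or a primary amide in its place, would keep this number. Also open, on these data alone, is whether hydrogen in place of fluoro on the aromatic carbon would remain within the scatter with 4-(carboxymethyl)cyclohexyl present.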